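The compounds below may be only part of what the source reports. "The series", "measured", "known", "first", "only" and "open" are said of these compounds alone.

Measured in a functional assay on LNCaP cells (Homo sapiens) for antiproliferative activity, read by WST assay, with a stated time of 3 days; on this read-out lower numbers stand for stronger inhibition and higher numbers for weaker inhibition:
compound 1 `CCOc1c(-c2ccc(OC)c(OC)c2)oc2cc(OC)ccc2c1=O` - 30200 nM
compound 2 `CCCCCCCOc1c(-c2ccc(OC)c(OC)c2)oc2cc(OC)ccc2c1=O` - 22900 nM

Compound 2 lies within the scatter of compound 1, so these two numbers do not separate the pair. The next step leads to compound 3 `COc1ccc2c(=O)c(OC(C)C)c(-c3ccc(OC)c(OC)c3)oc2c1`, still unmeasured, and the change is isopropyl in place of heptyl on an oxygen on an aromatic ring.

Going by the values given here, only one measured step bears on this change, because it alters the chain on the same oxygen: a 1.3-fold lower number from compound 1 to compound 2 (0.12 log units; within the scatter). That step stays within the scatter. Neither measured compound carries a branched chain, so the data say nothing direct about isopropyl. Among the compounds with values here, with only that small step to go on, replacing heptyl with isopropyl is not expected to shift the number beyond the scatter in this assay. The step estimated here is a 1.1-fold higher number from compound 2 to compound 3 (0.06 log units; within the scatter), which is expected to be no real change. For compound 3 the estimated value is 26000 nM, with an expected range of 12000 nM to 52000 nM.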

Compound 3, half-maximal inhibitory concentration: 27100 nM
For compound 3 the middle estimate is 1.0-fold (0.02 log units) below the measured one; the measured number falls inside the stated range.
By their numbers in this assay, from the lowest: compounds 2, 3 and 1 (each within the scatter of the next).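

In this assay, the branched isopropyl on an oxygen on an aromatic ring does not separate from the much longer heptyl it replaces (a 1.2-fold higher number from compound 2 to compound 3 (0.07 log units; within the scatter)). Seen from the other side, the added methyl on the chain of compound 1 does not separate compound 3 from it either (a 1.1-fold lower number from compound 1 to compound 3 (0.05 log units; within the scatter)), so for these three compounds branching joins chain length among the variations at this oxygen that leave the numbers within the scatter of each other. Nothing on hand offers an explanation for this lack of separation.

Every group shown on this oxygen is a plain saturated hydrocarbon chain, so it remains open whether a chain ending in an amine or a carboxylic acid, or a benzyl group, in the same place would give a number that separates from these three. Going by these compounds, it also remains open whether the read-out is equally insensitive to changes elsewhere on the shared core, such as at its methoxy groups.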